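Adding a Second Trifluoromethyl Group to Compound 3

A few compounds are considered here, and "the series" means these few. Any claim that something is new, unique, unknown or untested is made for them only; others in the source may bear on it.

Of the compounds shown here, three have been tested in an ADME assay on isolated protein for inhibition of cytochrome c oxidase subunit 2 (Homo sapiens), read by ELISA, tested at 100 uM; a lower number here means less inhibition, a higher number more inhibition at the concentration tested (going by the name of the read-out). Compound 1 `COc1ccc(Cn2nnc(O)c2C(=O)Nc2cccc(C(F)(F)F)c2)cc1OC` gives 0.87%, and compound 2 `O=C(Nc1cccc(C(F)(F)F)c1)c1c(O)nnn1Cc1ccc(OC(F)(F)F)cc1` gives 0%. Compound 3 `Oc1noc2cccc(Nc3cccc(C(F)(F)F)c3)c12` gives 13%, the highest of the three numbers; its gaps to compound 1 and to compound 2 both lie beyond the usual scatter of repeated measurements. Compound 4 `Oc1noc2cccc(Nc3cc(C(F)(F)F)cc(C(F)(F)F)c3)c12` has not yet been measured. It differs from compound 3 in one place: trifluoromethyl in place of hydrogen on an aromatic carbon. Going by the values given here, no measured pair in this set shows what such a change does here, so the direction of the step is open. The expected step is small, a number 3 percentage points higher from compound 3 to compound 4 (within the scatter), and may well stay within the scatter. Compound 4 is therefore estimated at 16%, within a range from 3% to 32%.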

Compound 4, a percentage reported as inhibition, at one concentration (the size of the read-out at that concentration, not a potency): 0%
Estimate against measurement, compound 4: 16 percentage points above, outside the stated range (below it).
By their numbers in this assay, from the lowest: compounds 2, 4 and 1 (each within the scatter of the next); then compound 3.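

In this assay, putting trifluoromethyl in place of hydrogen, meta to the existing trifluoromethyl group, gives a number 13 percentage points lower from compound 3 to compound 4 (beyond the scatter). Going by these compounds alone, this is the first one-place step in the set, and it shows that the read-out responds to what sits on this aromatic carbon. Nothing measured here explains the drop.

Still open, from the compounds shown here alone, is whether a methyl group or a chlorine atom on the same carbon would lower the number as well. A carboxylic acid or an amine there is equally unresolved.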